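The compounds below may be only part of what the source reports. "The series", "measured", "known", "first", "only" and "open" are said of these compounds alone.

In a functional assay on the whole organism (Tail, strain ICR) with Mus musculus as the target, in the tail flick test, with a stated time of 120 min, at a dose of 25 umol/kg by the oral route (on this read-out higher numbers stand for a stronger effect at the one dose given and lower numbers for a weaker effect), compound 3 `N=C(N)NCCC[C@H](NC(=O)CN(c1ncnc2c1ncn2C1CCCCO1)C1CC1)C(=O)OCc1ccccc1` gives 38.2%, the highest of the three numbers. Compound 2 `O=C(CN(c1ncnc2c1ncn2C1CCCCO1)C1CC1)N[C@@H](CO)C(=O)OCc1ccccc1` gives 29.2% in this assay, and a number 9 percentage points higher from compound 2 to compound 3 (within the scatter). Compound 1 `C[C@@H](O)[C@H](NC(=O)CN(c1ncnc2c1ncn2C1CCCCO1)C1CC1)C(=O)OCc1ccccc1` gives 10.9%, and a number 27.3 percentage points higher from compound 1 to compound 3 (beyond the scatter). Compound 4 `CC(C)[C@H](NC(=O)CN(c1ncnc2c1ncn2C1CCCCO1)C1CC1)C(=O)OCc1ccccc1` differs from compound 3 by a group of 3 heavy atoms (3 carbon; no ring) in place of a group of 7 heavy atoms (4 carbon, 3 nitrogen; no ring), on a saturated chain carbon bound to an amide-type nitrogen and a carbonyl carbon. The step that bears on this most directly is a number 27.3 percentage points higher from compound 1 to compound 3 (beyond the scatter), which brought in the group of 7 heavy atoms that now leaves; the smaller step of a number 9 percentage points higher from compound 2 to compound 3 (within the scatter) also removed a group without nitrogen. Reversing the larger of these suggests a fall beyond the scatter in this assay. Compound 4 is therefore expected to give about 18%, between 5% and 35%. This estimate means a step of a number 20.2 percentage points lower from compound 3 to compound 4 (beyond the scatter).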

Compound 4, a percentage reported as activity, at one dose (the size of the read-out at that dose, not a potency): 25.8%
Compound 4: the middle estimate sits 7.8 percentage points below what was measured, within the range that was stated.
By their numbers in this assay, from the lowest: compound 1; then compounds 4, 2 and 3 (each within the scatter of the next, the first and the last beyond it).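

In this assay isopropyl, with no hydrogen-bond donors or acceptors, shows a number 12.4 percentage points lower from compound 3 to compound 4 (beyond the scatter) and also a number 14.9 percentage points higher from compound 1 to compound 4 (beyond the scatter) at this position, so a group of carbon alone does not give the lowest number of the set. Against hydroxymethyl the result is a number 3.4 percentage points lower from compound 2 to compound 4 (within the scatter) and these two groups cannot be told apart here, while 1-hydroxyethyl stands apart from both. No measurement here accounts for these differences. As far as these compounds go, what an amine, a carboxylic acid or a longer alkyl chain would give at this place stays open, as does whether the nitrogen atoms or the length of the group in compound 3 goes with its higher number.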